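Iodo in place of phenyl on the bicyclic core

The source may report more compounds than this note shows. Statements on the series, on what has been measured and on what is new or still open speak of the compounds shown alone.

Compound 1 `Cc1ncnc2c1c(I)cn2[C@@H]1O[C@H](CO)[C@@H](O)[C@H]1O`: in a functional assay on K562 cells (Homo sapiens), read by MTT assay, with a stated time of 72 h (on this read-out lower numbers stand for stronger inhibition and higher numbers for weaker inhibition), compound 1 gives 17800 nM.
Compound 2 `COc1ncnc2c1c(-c1ccoc1)cn2[C@@H]1O[C@H](CO)[C@@H](O)[C@H]1O`: in this assay compound 2 gives 190 nM.
Compound 3 `COc1ncnc2c1c(-c1ccccc1)cn2[C@@H]1O[C@H](CO)[C@@H](O)[C@H]1O`: in this assay compound 3 gives > 20000 nM, which is a limit of the assay and not a number.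

Compound 3 therefore stands only at the limit of > 20000 nM in this assay, at which 1 of the 3 values shown sits, with no measured number of its own. Compound 4 `COc1ncnc2c1c(I)cn2[C@@H]1O[C@H](CO)[C@@H](O)[C@H]1O` differs from compound 3 in one place: iodo in place of phenyl on an aromatic carbon. The measured step bearing on this position is an at least 100-fold higher number from compound 2 to compound 3 (2.02 log units; beyond the scatter), showing that the group on that carbon can shift the read-out strongly. Compound 1, which also carries iodo there, gives 17800 nM. A step toward lower numbers is therefore expected in this assay, of the size an at least 2.0-fold lower number from compound 3 to compound 4 (0.30 log units; that floor lies within the scatter), its exact size uncertain since compound 3 is a limit. Compound 4 is estimated at 10000 nM, within 3000 nM to 30000 nM.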

Compound 4, half-maximal inhibitory concentration: > 20000 nM
Compound 4 gave a limit, no number (the forecaster's own chance of this, stated with the estimate: 25%); middle value at least 2.0-fold (0.30 log units) from the limit.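

With methoxy on the core, iodo leaves compound 4 at a limit of the assay, as phenyl does in compound 3: the limit of > 20000 nM in this assay, at which 2 of the 4 values shown sit.

Furan-3-yl therefore stands apart from both groups, with an at least 100-fold higher number from compound 2 to compound 4 (2.02 log units; beyond the scatter), while the step between the two limits cannot be read. Methoxy in place of methyl gives an at least 1.1-fold higher number from compound 1 to compound 4 (0.05 log units; that floor lies within the scatter), so this change is not shown to exceed the scatter.

From the compounds shown here alone, what thiophen-3-yl or an amine would give on that carbon stays open, as does whether methyl in place of methoxy would preserve the number of compound 2.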